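This account rests on a few compounds, and the source may have more. Where it says the series, first, only, none or still open, it means among the compounds named here.

Measured so far in a physicochemical assay for solubility, measured as thermodynamic solubility, at pH 7.4; on this read-out higher numbers stand for higher solubility and lower numbers for lower solubility:
compound 1 `O=C(O)Cn1nc(Cc2nc3cc(Cl)c(OCC(F)F)cc3[nH]2)c2ccccc2c1=O` — > 1000 ug/mL
compound 2 `CC(C(=O)O)c1nn(Cc2cn3cc(OCC4CC4)c(C(F)(F)F)cc3n2)c2ccccc2c1=O` — 221 ug/mL

In this assay compound 1 gives > 1000 ug/mL, which is a limit of the assay and not a number. Compound 2 gives 221 ug/mL in this assay. Going by the values given here, compound 1 and compound 2 differ in more than one place; no single step between them is given, and the pair shows only these two values. Compound 1 thus stands at the upper edge of what this assay reports, as the limit of > 1000 ug/mL in this assay, at which 1 of the 2 values shown sits, records, with no number of its own.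

Compound 3 `O=C(O)Cn1nc(Cc2nc3cc(Cl)c(OCC4CC4)cc3[nH]2)c2ccccc2c1=O` differs from compound 1 by cyclopropyl in place of difluoromethyl on a saturated chain carbon bound to an oxygen on an aromatic ring. With no measured step of this kind in the set, a downward step of moderate size in this assay, beyond the scatter, is expected, an at least 2.5-fold lower number from compound 1 to compound 3 (0.39 log units; beyond the scatter). Compound 3 is estimated at 400 ug/mL, with a range from 120 ug/mL to 1000 ug/mL.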

Compound 3, solubility: 395 ug/mL
Beside the measured number, compound 3's estimate is 1.0-fold (0.01 log units) above it, within the range that was stated.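

In this assay, cyclopropyl in place of difluoromethyl on a saturated chain carbon bound to an oxygen on an aromatic ring gives an at least 2.5-fold lower number from compound 1 to compound 3 (0.40 log units; beyond the scatter). Going by these compounds alone, this is the first read step at this position, and it arises between two groups with the same count of heavy atoms, neither carrying a hydrogen-bond donor, a hydrogen-bond acceptor or a net charge. The step can be read in one direction only, as a minimum size, because compound 1 stands at a limit and not at a number: the limit of > 1000 ug/mL in this assay, at which 1 of the 3 values shown sits.

This single pair does not separate the loss of the two fluorine atoms from the entry of the three-membered ring. As far as these compounds go, how a plain ethyl chain, a longer chain or an amine would read at this position remains open.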